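Replacing nitro with trifluoromethyl on the shared core

A few compounds are considered here, and "the series" means these few. Any claim that something is new, unique, unknown or untested is made for them only; others in the source may bear on it.

Compound 3 `O=C(Nc1ccccc1[N+](=O)[O-])N[C@H]1CC[C@H](Oc2ccc(F)cc2)CC1` is tested in a functional assay on CRL2813 cells (Homo sapiens) for cytotoxicity, read by sulforhodamine B assay, with a stated time of 5 days (a higher number here means a weaker inhibitor, a lower number a stronger inhibitor), and gives 3500 nM. Compound 1 `O=C(Nc1ccc(I)cc1)N[C@H]1CC[C@H](Oc2ccc(F)cc2)CC1` gives 10200 nM in the same assay. Compound 2 `O=C(Nc1ccc(Br)cc1)N[C@H]1CC[C@H](Oc2ccc(F)cc2)CC1` reaches only a limit of the assay, > 20000 nM, rather than a number (the limit of > 20000 nM in this assay, at which 1 of the 3 values shown sits). Among the numbers shown, compound 3 therefore has the lowest, with compound 1 nearest at a 2.9-fold lower number from compound 1 to compound 3 (0.46 log units; beyond the scatter).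

Compound 4 `O=C(Nc1ccccc1C(F)(F)F)N[C@H]1CC[C@H](Oc2ccc(F)cc2)CC1` differs from compound 3 in one place: trifluoromethyl in place of nitro on an aromatic carbon.

Going by the values given here, no measured step swaps one group for another on the same aromatic ring in this way. The steps that exist change the whole aryl group: a 2.9-fold lower number from compound 1 to compound 3 (0.46 log units; beyond the scatter) and an at least 5.7-fold lower number from compound 2 to compound 3 (0.75 log units; beyond the scatter), while an at least 1.9-fold higher number from compound 1 to compound 2 (0.29 log units; that floor lies within the scatter) stays within the scatter. These show the aryl part shifts the number only modestly, so a small step is expected, with a slight rise in the number as the more likely direction.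

Compound 4 is estimated at 5500 nM, with a range from 2000 nM to 16000 nM, an expected step of a 1.6-fold higher number from compound 3 to compound 4 (0.20 log units; within the scatter).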

Compound 4, half-maximal inhibitory concentration: > 20000 nM
Compound 4: a limit, no number; the forecaster's own chance of this, stated with the estimate: 20%; at least 3.6-fold (0.56 log units) between middle value and limit.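

Swapping only the group on this aromatic carbon, ortho to a large group, gives an at least 5.7-fold higher number from compound 3 to compound 4 (0.75 log units; beyond the scatter). The earlier steps shown here all replaced the whole aryl group, so this step shows that a change of one group on the ring, with the rest of compound 3 kept, is enough to lose a measurable number. Compound 4 gives only a limit in this assay, not a number, so the step has a floor but no known size, and the compound stands at the same limit as compound 2: the limit of > 20000 nM in this assay, at which 2 of the 4 values shown sit.

As far as these compounds go, it remains open whether another group at this carbon, such as an amine, a nitrile or a carboxylic acid, would keep a measurable number as nitro does. Compound 2 and compound 4 both end in limits, so no order between them can be read.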